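The compounds below may be only part of what the source reports. "The series", "measured", "known", "first", "only" and "open" are said of these compounds alone.

Measured in a functional assay on a cell-free system (plasma, Homo sapiens) for inhibition, with Plasma (Rattus norvegicus) as the target; a higher number here means a weaker inhibitor, a lower number a stronger inhibitor:
- compound 1 `Cc1c(OCc2cccnc2)ccc2c(N3CCNCC3)cc(=O)oc12`: 980 nM
- compound 2 `CCCOc1ccc2c(N3CCNCC3)cc(=O)oc2c1C`: 2950 nM
- compound 3 `COCOc1ccc2c(N3CCNCC3)cc(=O)oc2c1C`: 2300 nM

Compound 3, at 2300 nM, has the second highest of the three numbers. It is level with compound 2 within the scatter, as a 1.3-fold lower number from compound 2 to compound 3 (0.11 log units; within the scatter) shows, and clearly above compound 1, as a 2.3-fold higher number from compound 1 to compound 3 (0.37 log units; beyond the scatter) shows.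

The next compound is compound 4 `Cc1c(OCC2CCCN(C)C2)ccc2c(N3CCNCC3)cc(=O)oc12`, which has 1-methylpiperidin-3-yl in place of methoxy on a saturated chain carbon bound to an oxygen on an aromatic ring.

Among the compounds with values here, the closest evidence comes from compound 1, the only measured compound with a ring at this place. Its modest steps are a 3.0-fold higher number from compound 1 to compound 2 (0.48 log units; beyond the scatter) and a 2.3-fold higher number from compound 1 to compound 3 (0.37 log units; beyond the scatter). Within the data shown here, no measured compound has a non-aromatic ring there, so this comparison is only a loose guide. A modest step to a lower number is therefore expected, though none beyond the scatter remains possible.

The expected step is a 1.8-fold lower number from compound 3 to compound 4 (0.25 log units; within the scatter).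

The estimate for compound 4 is 1300 nM, with an expected range of 450 nM to 3500 nM.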

Compound 4, half-maximal inhibitory concentration: 4700 nM
For compound 4 the middle estimate is 3.6-fold (0.56 log units) below the measured one; the measured number lies above the stated range.
By their numbers in this assay, from the lowest: compound 1; then compounds 3, 2 and 4 (each within the scatter of the next, the first and the last beyond it).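

In this assay, a ring at this place does not by itself give the low number seen with the pyridin-3-yl group: the saturated 1-methylpiperidin-3-yl group gives a 2.0-fold higher number from compound 3 to compound 4 (0.31 log units; beyond the scatter), and the gap to the aromatic ring is a 4.8-fold higher number from compound 1 to compound 4 (0.68 log units; beyond the scatter), the largest step among the four compounds. Against ethyl, the same group stays level, at a 1.6-fold higher number from compound 2 to compound 4 (0.20 log units; within the scatter), so its ring and larger atom count bring no gain over the open chain. No measurement shown accounts for the difference between the two rings.

The compounds shown leave open whether the ring nitrogen of the pyridin-3-yl group matters at all, which phenyl at this place would test. They also leave open how a carboxylic acid or a longer chain there would read.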